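The source may report more compounds than this note shows. Statements on the series, on what has been measured and on what is new or still open speak of the compounds shown alone.

Compound 1 `Cc1ccc(NC(=O)c2cnc(Cl)nc2C(F)(F)F)s1` gives 2300 nM in an assay on Jurkat cells for inhibition of nuclear factor NF-kappa-B p105 subunit (Homo sapiens); a higher number here means a weaker inhibitor, a lower number a stronger inhibitor. Compound 2 `NC(=O)c1cc(NC(=O)c2cnc(Cl)nc2C(F)(F)F)cc(C(F)(F)F)c1` gives 5000 nM in this assay. Compound 3 `CCCCNC(=O)c1cc(NC(=O)c2cnc(Cl)nc2C(F)(F)F)cc(C(F)(F)F)c1` is reported in this assay only as a limit, > 10000 nM. Within the data shown here, the step of an at least 2.0-fold higher number from compound 2 to compound 3 (0.30 log units; that floor lies within the scatter) is the only measured change at that amide position, and its floor alone is certain. Compound 4 `CCCCCCCCOC(=O)c1cc(NC(=O)c2cnc(Cl)nc2C(F)(F)F)cc(C(F)(F)F)c1` differs from compound 3 by octyloxy in place of butylamino on a carbonyl carbon. Among the measured compounds shown here, no measured pair covers an ester or a longer chain at this carbonyl, so the expectation rests on compound 3 already sitting at the limit (the limit of > 10000 nM in this assay, at which 1 of the 3 values shown sits). Compound 4 is therefore expected to remain weak, with an estimated step that the limit leaves unreadable from compound 3 to compound 4 that does not go beyond the scatter. The estimate for compound 4 in this assay is 15000 nM, between 5000 nM and 50000 nM.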

Compound 4, half-maximal inhibitory concentration: 1800 nM
The estimate for compound 4 lay 8.3-fold (0.92 log units) above the measured number; the whole stated range lies above it.
By their numbers in this assay, from the lowest: compounds 4 and 1 (each within the scatter of the next); then compound 2. At a limit, above all of these: compound 3.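

The carbonyl position still tolerates activity: octyloxy in place of butylamino gives an at least 5.5-fold lower number from compound 3 to compound 4 (0.74 log units; beyond the scatter), and octyloxy in place of amino gives a 2.8-fold lower number from compound 2 to compound 4 (0.44 log units; beyond the scatter). A longer chain here therefore does not by itself weaken the compound, as compound 4 shows. Compound 3 is reported only as a limit, so only a floor is known for the first step: the limit of > 10000 nM in this assay, at which 1 of the 4 values shown sits.

Each step changes the atom joined to the carbonyl and the chain together, and the compounds shown do not separate the two. On these data alone, a butyl ester, an octyl amide and a carboxylic acid at this carbonyl remain open.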